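Methyl for hydrogen on the five-membered ring, compound 2 to 3

The source may report more compounds than this note shows. Statements on the series, on what has been measured and on what is new or still open speak of the compounds shown alone.

Measured compounds:
compound 1, `Cc1cc(-c2ccccc2)n(/C(N)=N/S(=O)(=O)c2cc(C)c(Cl)cc2SCc2ccccc2C)n1`, 42000 nM
compound 2, `Cc1cc(S(=O)(=O)/N=C(\N)n2nccc2-c2ccccc2)c(SCc2ccccc2Cl)cc1Cl`, 18000 nM

In a functional assay on HCT-116 cells (Homo sapiens) for cytotoxicity, read by MTT assay, with a stated time of 72 h (a higher number here means a weaker inhibitor, a lower number a stronger inhibitor), compound 2 gives the lower of the two numbers, with 18000 nM; compound 1 gives 42000 nM, and the gap between the two lies beyond the scatter. Compound 3, `Cc1cc(-c2ccccc2)n(/C(N)=N/S(=O)(=O)c2cc(C)c(Cl)cc2SCc2ccccc2Cl)n1`, carries methyl in place of hydrogen on an aromatic carbon relative to compound 2. Going by the values given here, no measured pair shows this change, so no step beyond the scatter is expected in this assay in either direction. Compound 3 is estimated at 20000 nM, within 8000 nM to 50000 nM. The expected step from compound 2 to compound 3 is a 1.1-fold higher number from compound 2 to compound 3 (0.05 log units; within the scatter).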

Compound 3, half-maximal inhibitory concentration: 170000 nM
For compound 3 the middle estimate is 8.5-fold (0.93 log units) below the measured one; the whole stated range lies below it.
By their numbers in this assay, from the lowest: compound 2; then compound 1; then compound 3.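

In this assay, the aromatic carbon of the five-membered ring, two ring bonds from the ring atom that bears a phenyl group, proves sensitive to a single added carbon: methyl in place of hydrogen gives a 9.4-fold higher number from compound 2 to compound 3 (0.98 log units; beyond the scatter) in this series. With that methyl present, chloro in place of methyl on an aromatic carbon elsewhere gives a 4.0-fold higher number from compound 1 to compound 3 (0.61 log units; beyond the scatter) as a second step in the same direction. Nothing at hand explains either step.

Still open, as far as these compounds go, is whether ethyl, methoxy or an amine on this ring carbon would behave as methyl does. Also open, from the compounds shown here alone, is whether the methyl step keeps its size with other groups at the chloro position.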